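The source may hold more compounds than are shown below. What is called first, only, known or untested is meant among the compounds shown, and "the series" means these compounds.

Measured so far in a functional assay on the whole organism (strain Sprague-Dawley) for inhibition, with Rattus norvegicus as the target, with a stated time of 10 min; a higher number here means that more compound is needed for the effect, a lower number that less compound is needed:

Compound 1 `O=C(O)c1cnc(-c2ccc(Cl)cc2)[nH]c1=O` gives 5 mg/kg.
Compound 2 `CCOC(=O)c1cnc(-c2ccc(Cl)cc2)[nH]c1=O` reaches only a limit of the assay, > 30 mg/kg.
Compound 3 `Cn1c(-c2ccccc2)ncc(C(=O)O)c1=O` gives 50 mg/kg.

Compound 1 and compound 2 share one core and differ in a single place: ethyl in place of hydrogen on an oxygen next to a carbonyl group. That change gives an at least 6.0-fold higher number from compound 1 to compound 2 (0.77 log units; beyond the scatter); the size of this step is bounded by the limit of > 30 mg/kg in this assay, at which 1 of the 3 values shown sits, since compound 2 does not yield a number. Compound 3 carries a different core; the difference between the two cores is not broken down here. Its value stands as the highest of the two numbers, a step beyond the scatter from compound 1.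

Compound 4 `CCOC(=O)c1cnc(-c2ccccc2)n(C)c1=O` is not yet measured. It differs from compound 3 in the same way that compound 2 differs from compound 1: ethyl in place of hydrogen on an oxygen next to a carbonyl group. The place of the change reads the same word for word in both pairs, so this is the same change. For compound 4 the expectation rests on the step from compound 1 to compound 2, an at least 6.0-fold higher number from compound 1 to compound 2 (0.77 log units; beyond the scatter), applied to the starting value of compound 3, 50 mg/kg. The expected step is a 6.0-fold higher number from compound 3 to compound 4 (0.78 log units; beyond the scatter). Compound 4 is therefore estimated at 300 mg/kg, with a plausible range from 100 mg/kg to 1000 mg/kg, and it is expected that this assay will most likely report only a limit for it.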

Compound 4, dose for 50% inhibition: > 5 mg/kg
Compound 4: only a limit was reported; the forecaster's own chance of this, stated with the estimate: 85%; the middle value is on the limit's open side.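

In this assay compound 4 gives only a limit, > 5 mg/kg. Among these compounds, no step from compound 3 to compound 4 can be read from it. The compounds shown leave open whether ethyl in place of hydrogen on an oxygen next to a carbonyl group gives a higher number on the core of compound 3, as it does on the core of compound 1.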